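Swapping 4-fluorophenyl for cycloheptyl on the lead compound

A few compounds are considered here, and "the series" means these few. Any claim that something is new, unique, unknown or untested is made for them only; others in the source may bear on it.

The core is shared by three compounds that have been measured in a functional assay on MCF7 cells (Homo sapiens) for cytotoxicity, read by WST assay, with a stated time of 72 h; a higher number here means a weaker inhibitor, a lower number a stronger inhibitor. Compound 3 `COc1ccc2c(c1C)NC(=O)C2(c1ccc(O)cc1)c1ccc(F)cc1` gives 6.3 nM, the lowest number in the set. Compound 1 `O=C1Nc2c(ccc(F)c2F)C1(CC1CCCCC1)c1ccc(O)cc1` gives 102 nM, a gap from compound 3 that lies beyond the scatter. Compound 2 `Cc1cccc2c1NC(=O)C2(c1ccc(O)cc1)C1CCCCCC1` reads > 1000 nM, which is a limit of the assay and not a number.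

Compound 4 `COc1ccc2c(c1C)NC(=O)C2(c1ccc(O)cc1)C1CCCCCC1` follows from compound 3 by one change: cycloheptyl in place of 4-fluorophenyl on a saturated ring carbon. Among the compounds with values here, no measured pair isolates this change. The expectation leans on compound 2, which also carries cycloheptyl and stands at the limit of > 1000 nM. Compound 3, at 6.3 nM, leaves plenty of room for a loss while still giving a measurable number.

A large step towards a higher number in this assay is expected, estimated as a 13-fold higher number from compound 3 to compound 4 (1.10 log units; beyond the scatter). For compound 4 the estimated value is 80 nM, with an expected range of 15 nM to 500 nM.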

Compound 4, half-maximal inhibitory concentration: 4.7 nM
For compound 4 the middle estimate is 17-fold (1.23 log units) above the measured one; the measured number lies below the stated range.
By their numbers in this assay, from the lowest: compounds 4 and 3 (each within the scatter of the next); then compound 1. At a limit, above all of these: compound 2.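

In this assay, the saturated ring carbon on the core of compound 3 accepts cycloheptyl in place of 4-fluorophenyl with a 1.3-fold lower number from compound 3 to compound 4 (0.13 log units; within the scatter), so in this pair an aromatic ring at this position is not needed for a low number. Cycloheptyl therefore does not go with a high number on its own: with cycloheptyl held constant, methoxy in place of hydrogen on an aromatic carbon gives an at least 210-fold lower number from compound 2 to compound 4 (2.32 log units; beyond the scatter). The reading for compound 2 is a limit and not a number, so the size of that step is only a bound: the limit of > 1000 nM in this assay, at which 1 of the 4 values shown sits.

On these data alone, whether the same carbon also accepts a small ring such as cyclopropyl, or a ring carrying an amine, remains open. As far as these compounds go, it is equally open whether ethoxy or an amine can stand in for methoxy on the aromatic carbon.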